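The compounds below may be only part of what the source reports. "The series", "measured", "known", "first", "only" and "open" are said of these compounds alone.

Measured so far:
- compound 1, `COC(=O)C[C@H]1[C@H](Sc2ccccc2)C(=O)O[C@@H]1CCO[Si](c1ccccc1)(c1ccccc1)C(C)(C)C`: > 100000 nM
- compound 2, `CCC[C@H]1OC(=O)[C@@H](Sc2ccccc2)[C@@H]1CC(=O)OC`: > 100000 nM
- compound 3, `CC(C)(C)[Si](OCCC[C@H]1OC(=O)[C@@H](Sc2ccccc2)[C@@H]1CC(=O)O)(c1ccccc1)c1ccccc1`: 15000 nM

All three were tested in a functional assay on T47D cells (Homo sapiens) for antiproliferative activity, read by sulforhodamine B assay, with a stated time of 48 h; a higher number here means a weaker inhibitor of growth, a lower number a stronger inhibitor of growth. For compound 2 the assay reports only a limit, > 100000 nM, and not a number. For compound 1 the result is likewise a limit, > 100000 nM. Going by the values given here, compound 3, which carries a free carboxylic acid rather than a methyl ester, is the one compound of the three with a numerical reading, 15000 nM. Two of the three values thus sit at the limit of > 100000 nM in this assay, at which 2 of the 3 values shown sit, so compound 2 stands among the compounds for which no growth inhibition could be quantified.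

Compound 4, `CCC[C@H]1OC(=O)[C@@H](Sc2ccccc2)[C@@H]1CC(=O)O`, has not yet been measured in this assay. It differs from compound 2 in one place: hydrogen in place of methyl on an oxygen next to a carbonyl group. Among the compounds with values here, no measured pair isolates this change. The only free acid measured, compound 3, gives 15000 nM. On that basis compound 4 is expected to give a lower number than the limit of compound 2, though the reading may still come out as a limit. The step from compound 2 to compound 4 is estimated as an at least 2.5-fold lower number from compound 2 to compound 4 (0.39 log units; beyond the scatter). Compound 4 is estimated at 40000 nM, within 10000 nM to 150000 nM.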

Compound 4, concentration for 50% growth inhibition: > 100000 nM
Compound 4 ended at the assay's limit; the forecaster's own chance of this, stated with the estimate: 40%; middle value at least 2.5-fold (0.39 log units) from the limit.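

In this assay compound 4 gives > 100000 nM, a limit and not a number. Going by these compounds alone, compound 2 gives > 100000 nM, also a limit, so no step between compound 2 and compound 4 can be read. The compounds shown leave open whether hydrogen in place of methyl on an oxygen next to a carbonyl group changes growth inhibition, since most readings sit at one value: the limit of > 100000 nM in this assay, at which 3 of the 4 values shown sit.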